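Imidazole regioisomers in a serine protease 1 amidine series

The source may hold more compounds than are shown below. What is called first, only, known or untested is meant among the compounds shown, and "the series" means these compounds.

Compound 1 `CC(C)(C)c1ccc(C(=O)NCCCc2cc(C(=N)N)ccc2O)cc1`: 2200 nM
Compound 2 `N=C(N)c1ccc(O)c(CCCNC(=O)c2ccc(-c3ncc[nH]3)cc2)c1`: about 2900 nM

Of the compounds shown here, two have been measured in an assay on isolated protein for inhibition of serine protease 1 (Homo sapiens); on this read-out lower numbers stand for stronger inhibition and higher numbers for weaker inhibition. Compound 1 `CC(C)(C)c1ccc(C(=O)NCCCc2cc(C(=N)N)ccc2O)cc1` gives 2200 nM, and compound 2 `N=C(N)c1ccc(O)c(CCCNC(=O)c2ccc(-c3ncc[nH]3)cc2)c1` gives about 2900 nM. Compound 2 holds the higher of the two numbers, but the gap to compound 1 is small: the step of a 1.3-fold higher number from compound 1 to compound 2 (0.12 log units; within the scatter) lies within the scatter, so the two cannot be ordered.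

Compound 3 `N=C(N)c1ccc(O)c(CCCNC(=O)c2ccc(-c3c[nH]cn3)cc2)c1` has not yet been measured. It differs from compound 2 only in how the same atoms are joined: 1H-imidazol-4-yl in place of 1H-imidazol-2-yl on an aromatic carbon. For the measured compounds named here, the single measured step, from compound 1 to compound 2, swapped a very different group at this position and produced no change beyond the scatter; no step with an imidazole regioisomer is available. On this basis, no step beyond the scatter is expected for compound 3, and its inhibition constant in this assay is estimated at 2900 nM (range 1200 nM to 7000 nM). The expected step of no change at the digits printed from compound 2 to compound 3 (within the scatter) is thus essentially flat.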

Compound 3, inhibition constant: about 2900 nM
The estimate for compound 3 equals the measured number at the digits printed; the measured number falls inside the stated range.
By their numbers in this assay, from the lowest: compounds 1, 2 and 3 (each within the scatter of the next).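

In this assay, for the compounds shown here, changing only how the imidazole is joined to the ring gives no change at the digits printed from compound 2 to compound 3 (within the scatter), so this pair offers the first direct comparison of two imidazole regioisomers on this aromatic carbon, para to a large group, and the read-out does not separate them. The step of a 1.3-fold higher number from compound 1 to compound 3 (0.12 log units; within the scatter) adds a second imidazole replacement for tert-butyl that stays within the scatter, so the flat reading of the earlier pair no longer rests on 1H-imidazol-2-yl alone, and tert-butyl, 1H-imidazol-2-yl and 1H-imidazol-4-yl cannot be ordered here. No independent data bear on this result.

The three compounds leave open whether any group at this position can move the number beyond the scatter, as all three groups seen here sit within it. A carboxylic acid, a primary amine or an imidazole joined through a ring nitrogen, 1H-imidazol-1-yl, on the same aromatic carbon would show whether this flat reading extends beyond these groups or is limited to them.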